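The source may hold more compounds than are shown below. What is called first, only, known or untested is meant among the compounds shown, and "the series" means these compounds.

Measured in a functional assay on HeLa cells (Homo sapiens) for inhibition, read by CCK-8 assay, with a stated time of 48 h; a lower number here means a stronger inhibitor, a higher number a weaker inhibitor:
- compound 1 `Cc1cc(C)cc(NC(=O)NCCNS(=O)(=O)c2ccc(-c3ccccc3Oc3ccc([N+](=O)[O-])c([N+](=O)[O-])c3)s2)c1`: 12000 nM
- compound 2 `O=C(NCCNS(=O)(=O)c1ccc(-c2ccccc2OCc2cccc(O)c2)s1)Nc1cc(Cl)cc(Cl)c1`: > 50000 nM (a limit of the assay, not a number)
- compound 3 `O=[N+]([O-])c1cccc(NC(=S)NCCNS(=O)(=O)c2ccc(-c3ccccc3OCc3cccc(O)c3)s2)c1`: 11100 nM

Compound 3 and compound 1 lie within the scatter of each other in this assay, and the only other result is the limit for compound 2. The next compound is compound 4 `Cc1cc(C)cc(NC(=O)NCCNS(=O)(=O)c2ccc(-c3ccccc3OCc3cccc(O)c3)s2)c1`, and the change is a group of 11 heavy atoms (9 carbon, 1 nitrogen, 1 oxygen; one six-membered aromatic ring of carbon only) in place of a group of 12 heavy atoms (7 carbon, 2 nitrogen, 2 oxygen, 1 sulfur; one six-membered aromatic ring of carbon only), on an amine nitrogen. Within the data shown here, one measured step bears on this place: an at least 4.5-fold lower number from compound 2 to compound 3 (0.65 log units; beyond the scatter). That step lies beyond the scatter, and its size is only a bound. In it, the group that now leaves came in on the same amine nitrogen, so its removal is expected to move the number upward in this assay. Compound 1 carries the entering (3,5-dimethylphenyl)carbamoyl group on a different remainder and gives 12000 nM, which argues against assuming a full loss. A modest rise, beyond the scatter but not certain to be, is therefore expected. The estimated step is a 2.3-fold higher number from compound 3 to compound 4 (0.35 log units; beyond the scatter). For compound 4 the expected value is 25000 nM, with an estimated range from 10000 nM to 50000 nM.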

Compound 4, half-maximal inhibitory concentration: > 20000 nM
Compound 4 ended at the assay's limit (the forecaster's own chance of this, stated with the estimate: 30%); the middle value is on the limit's open side.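

In this assay compound 4 is held by a limit of the assay, not a number: the limit of > 20000 nM in this assay, at which 1 of the 4 values shown sits.

The change on the amine nitrogen therefore gives only floors, an at least 1.8-fold higher number from compound 3 to compound 4 (0.25 log units; that floor lies within the scatter) and an at least 1.6-fold higher number from compound 1 to compound 4 (0.22 log units; that floor lies within the scatter), and since both floors lie within the scatter, neither step by itself establishes a real loss. The step between compound 2 and compound 4 cannot be read, but the new result adds that, of the three compounds sharing the 3-hydroxybenzyl remainder, compound 2 and compound 4 both end at limits and only compound 3 gives a number, with compound 3 as the exception to any reading of this remainder as inactive.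

From the compounds shown here alone, the true size of the step to compound 4 stays open, as does which part of the leaving group matters, the thiocarbonyl or the nitro-bearing ring, as the two differ together between compound 3 and compound 4. Also open, going by these compounds, is whether a carboxylic acid or an amine on that aromatic ring would give a number on this remainder.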